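Carboxy for hydroxy: notes toward compound 4

The source may hold more compounds than are shown below. What is called first, only, known or untested is meant among the compounds shown, and "the series" means these compounds.

In a functional assay on Hep 3B2 cells (Homo sapiens) for antiproliferative activity, read by MTT assay, with a stated time of 24 h, tested at 0.01 ug/mL (a lower number here means a weaker effect, a higher number a stronger effect of the compound at the concentration tested), compound 1 `Cc1c(C(=O)Nc2c(F)cc(-c3cccc(F)c3)cc2F)nc2ccc(F)cc2c1O` gives -0.12%. Compound 3 `Cc1c(C(=O)Nc2c(F)cc(-c3cccc(F)c3)cc2F)nc2ccc(F)cc2c1C(=O)O` carries the change carboxy in place of hydroxy on an aromatic carbon and in this assay compound 3 gives -0.35%, the step being a number 0.2 percentage points lower from compound 1 to compound 3 (within the scatter). Compound 2 `COc1ccc2nc(C(=O)Nc3ccc(-c4ccccc4)cc3)c(C)c(O)c2c1` in this assay gives 0.35%; the difference between the cores of compound 1 and compound 2 is not broken down here, and the three values lie within the scatter of one another. Compound 4 `COc1ccc2nc(C(=O)Nc3ccc(-c4ccccc4)cc3)c(C)c(C(=O)O)c2c1` is not yet measured and differs from compound 2 by carboxy in place of hydroxy on an aromatic carbon, the same change as from compound 1 to compound 3, at a place described in the same words. In this assay the expected step is a number 0.2 percentage points lower from compound 2 to compound 4 (within the scatter), set beside a number 0.2 percentage points lower from compound 1 to compound 3 (within the scatter), because a number 0.2 percentage points lower from compound 1 to compound 3 (within the scatter) stayed within the scatter. Compound 4 is accordingly estimated at 0.15%, expected between -4% and 4%.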

Compound 4, a percentage reported as inhibition, at one concentration (the size of the read-out at that concentration, not a potency): -0.12%
Estimate against measurement, compound 4: 0.3 percentage points above; low and high end bracket the measured number.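

In this assay the new step is a number 0.5 percentage points lower from compound 2 to compound 4 (within the scatter). Carboxy in place of hydroxy on an aromatic carbon reads alike on the two cores: the same change on two cores in this assay, a number 0.2 percentage points lower (within the scatter) from compound 1 to compound 3 and a number 0.5 percentage points lower (within the scatter) from compound 2 to compound 4, 0.2 percentage points apart, within the scatter of two such steps. Going by these compounds alone, this shows only that neither step can be told from the scatter on these two cores; it does not show that the change would carry over where compounds give a clear effect, since at this single concentration no step is large enough to compare in size.

As far as these compounds go, an amine or a methyl ester at the same place, opposite the ring nitrogen, remains open on both cores. Also open, from the compounds shown here alone, is whether the carboxy for hydroxy step would stay alike on the two cores at a higher concentration.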